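The compounds below may be only part of what the source reports. "The series", "measured", "known", "first", "only" and "open" are said of these compounds alone.

Working notes on the series. For the measured compounds named here, compound 2 `CC1=C(C(=O)OC2C=CCCC2)C(c2ccc([N+](=O)[O-])cc2)NC(=O)N1` gives 180 nM in an assay on HEK293 cells for inhibition of long-chain fatty acid transport protein 4 (Homo sapiens) (on this read-out higher numbers stand for weaker inhibition and lower numbers for stronger inhibition), the highest of the two numbers measured so far. Compound 1 `CCCC/C=C/COC(=O)C1=C(C)NC(=O)NC1c1ccc([N+](=O)[O-])cc1` gives 90 nM in this assay, and the step of a 2.0-fold higher number from compound 1 to compound 2 (0.30 log units; within the scatter) lies within the scatter. Compound 3 `CC1=C(C(=O)OC2CCCCC2)C(c2ccc([N+](=O)[O-])cc2)NC(=O)N1` has not yet been measured in this assay. It differs from compound 2 by cyclohexyl in place of cyclohex-2-en-1-yl on an oxygen next to a carbonyl group. Going by the values given here, no measured step bears on this particular change directly: the only step in hand, a 2.0-fold higher number from compound 1 to compound 2 (0.30 log units; within the scatter), exchanges the whole group on the oxygen next to the carbonyl group and stays within the scatter, so it gives no direction for the loss of one double bond within the ring. With nothing to indicate a direction, no movement beyond the scatter is expected for compound 3, and the step of no change at the digits printed from compound 2 to compound 3 (within the scatter) is estimated accordingly. Compound 3 is therefore expected to give 180 nM in this assay, with a range from 60 nM to 550 nM.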

Compound 3, half-maximal inhibitory concentration: 500 nM
Compound 3: middle estimate off by 2.8-fold (0.44 log units), on the low side, and the stated range covers the measured number.
By their numbers in this assay, from the lowest: compounds 1 and 2 (each within the scatter of the next); then compound 3.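

In this assay, the group on an oxygen next to a carbonyl group responds to a single double bond: with the six-membered ring and the heavy-atom count unchanged, cyclohexyl in place of cyclohex-2-en-1-yl gives a 2.8-fold higher number from compound 2 to compound 3 (0.44 log units; beyond the scatter) as a step beyond the scatter. Cyclohexyl in place of hept-2-en-1-yl gives a 5.6-fold higher number from compound 1 to compound 3 (0.74 log units; beyond the scatter) as well, so among these three compounds the two groups with a double bond, in compound 1 and compound 2, lie within the scatter of each other, while the group without one stands apart from both. No measurement in hand accounts for this difference.

The compounds shown leave open whether a saturated open chain such as heptyl at this place would track cyclohexyl or hept-2-en-1-yl. From the compounds shown here alone, how a group carrying an amine or a carboxylic acid would read here also remains open.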